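Swapping a Triazole for an Isoxazole on a Shared Core

This account rests on a few compounds, and the source may have more. Where it says the series, first, only, none or still open, it means among the compounds named here.

Within the data shown here, compound 1, with the structure `O=C1Nc2ccc(-n3cncn3)cc2C(CNC(=O)c2ccc(F)cc2)(C(F)(F)F)O1`, is one of two compounds measured in an assay for inhibition of very long chain fatty acid elongase 6 (Homo sapiens); on this read-out lower numbers stand for stronger inhibition and higher numbers for weaker inhibition; there compound 1 gives 572 nM. That is the higher of the two numbers. The other measured compound, compound 2, with the structure `Cc1ccc(C(=O)NCC2(C(F)(F)F)OC(=O)Nc3ccc(Cl)cc32)cc1`, gives 38 nM in this assay, and the gap between these two values lies beyond the usual scatter, so compound 2 is the stronger inhibitor of the pair. Compound 2 differs from compound 1 in more than one place, so no single structural change can be tied to that gap.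

Compound 3, with the structure `O=C1Nc2ccc(-c3ccon3)cc2C(CNC(=O)c2ccc(F)cc2)(C(F)(F)F)O1`, has not yet been measured. It differs from compound 1 in one place: 1,2-oxazol-3-yl in place of 1H-1,2,4-triazol-1-yl on an aromatic carbon. Among the measured compounds shown here, with no measured single-change step available, only an expectation can be stated. The change from compound 1 to compound 3 is expected to lower the number a little, giving a step of a 1.8-fold lower number from compound 1 to compound 3 (0.25 log units; within the scatter), close to the edge of the scatter. Compound 3 is therefore estimated at 320 nM, within a range from 110 nM to 950 nM.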

Compound 3, half-maximal inhibitory concentration: 121 nM
Estimate against measurement, compound 3: 2.6-fold (0.42 log units) above; measured number inside the range.
By their numbers in this assay, from the lowest: compound 2; then compound 3; then compound 1.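

Among these compounds, with the rest of compound 1 held fixed, placing 1,2-oxazol-3-yl on this aromatic carbon instead of 1H-1,2,4-triazol-1-yl gives a 4.7-fold lower number from compound 1 to compound 3 (0.67 log units; beyond the scatter) in this assay, the first single-change step in this set and one that lies clear of the usual scatter. The step therefore shows that inhibition is sensitive to which five-membered aromatic ring sits here, even though both groups have 5 heavy atoms and differ in counted terms only in their ring atoms, with 2 hetero atoms and 2 hydrogen-bond acceptors in the entering group against 3 of each in the leaving group. Nothing measured here explains why this swap shifts the number.

Since compound 2 differs from compound 1 and compound 3 in more than one place, it cannot show how this position behaves on its own. A single step also leaves open how other groups would fare on the same carbon, such as a plain phenyl ring, a nitrile, an amine or a carboxylic acid, and whether the gain from 1,2-oxazol-3-yl would hold on a different amide side chain.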